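This account rests on a few compounds, and the source may have more. Where it says the series, first, only, none or still open, it means among the compounds named here.

The compounds measured in an assay on Sf21 cells for inhibition of ubiquitin carboxyl-terminal hydrolase 1 (Homo sapiens), read by fluorescence; a higher number here means a weaker inhibitor, a lower number a stronger inhibitor:
Compound 1 `O=C([C@H]1Cc2cc(Cl)cc(-c3ccnc4ccsc34)c2O1)N1CCNCC1` gives > 40000 nM, which is a limit of the assay.
Compound 2 `O=C([C@H]1Cc2cc(Cl)cc(-c3ccnc4cc(CO)sc34)c2O1)N1CCNCC1` gives > 40000 nM, also a limit.
Compound 3 `Cc1cc2nccc(-c3cc(Cl)cc4c3O[C@@H](C(=O)N3CCNCC3)C4)c2s1` gives > 80000 nM, again a limit.

Compound 1 therefore stands only at a limit in this assay, and the two further values are limits as well. The steps a step that the two limits leave unreadable from compound 1 to compound 2, a step that the two limits leave unreadable from compound 1 to compound 3 and a step that the two limits leave unreadable from compound 2 to compound 3 remain unreadable, the values sitting at the limit of > 40000 nM in this assay, at which 2 of the 3 values shown sit, and (the limit of > 80000 nM in this assay, at which 1 of the 3 values shown sits). Compound 4 `O=C([C@H]1Cc2cc(Cl)cc(-c3ccnc4[nH]ccc34)c2O1)N1CCNCC1` differs from compound 1 by a group of 9 heavy atoms (7 carbon, 2 nitrogen; one five-membered aromatic ring with 1 hetero atom, one six-membered aromatic ring with 1 hetero atom) in place of a group of 9 heavy atoms (7 carbon, 1 nitrogen, 1 sulfur; one five-membered aromatic ring with 1 hetero atom, one six-membered aromatic ring with 1 hetero atom), on an aromatic carbon. Within the data shown here, none of the measured steps bears readably on this change, so no step beyond the scatter in either direction is expected in this assay, and compound 4 is expected to sit near a limit once more. The estimate for compound 4 is 40000 nM, with a range from 5000 nM to 200000 nM. The expected step is a number no higher from compound 1 to compound 4 (the limit leaves the size open).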

Compound 4, half-maximal inhibitory concentration: > 80000 nM
Compound 4: only a limit was reported (the forecaster's own chance of this, stated with the estimate: 85%); middle value at least 2.0-fold (0.30 log units) away from the limit.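

Compound 1 and compound 4 both stand only at limits, so no step between them can be read: the limit of > 80000 nM in this assay, at which 2 of the 4 values shown sit.

The compounds shown leave open whether exchanging these groups changes inhibition at all, and how strongly any of the four compounds acts in this assay.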